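One Ring Stereocentre Inverted at Low Clearance

The source may report more compounds than this note shows. Statements on the series, on what has been measured and on what is new or still open speak of the compounds shown alone.

In an ADME assay on microsomes from liver (Mus musculus) for metabolic stability (a lower number here means slower removal, a higher number faster removal of the compound), compound 1 `CCO[C@@H]1O[C@H](CNC(=O)c2ccc(S(N)(=O)=O)cc2)[C@@H](O)[C@H](O)[C@H]1O` gives 1.54 mL/min/kg and so stands level, within the scatter, with compound 2 `CCCO[C@@H]1O[C@H](CNC(=O)c2ccc(S(N)(=O)=O)cc2)[C@@H](O)[C@H](O)[C@H]1O` at 1.53 mL/min/kg in the same measurement. Compound 3 `CCO[C@@H]1O[C@H](CNC(=O)c2ccc(S(N)(=O)=O)cc2)[C@@H](O)[C@H](O)[C@@H]1O` has not yet been measured. Set against compound 1, it shows the two compounds have the same atoms and bonds and differ only in configuration as drawn: 1 of 5 stereo elements differ; a stereocentre at a saturated ring carbon is drawn R in compound 1 and S in compound 3 and nothing else: a stereocentre at a saturated ring carbon is drawn R in compound 1 and S in compound 3. For the measured compounds named here, the only measured step, a 1.0-fold lower number from compound 1 to compound 2 (0.00 log units; within the scatter) (methyl in place of hydrogen on a saturated chain carbon), stays within the scatter. Going by the values given here, it bears only loosely on the question, since no measured pair differs in configuration. No shift beyond the scatter is therefore expected in this assay, and no direction can be favoured. The estimate is a 1.0-fold higher number from compound 1 to compound 3 (0.02 log units; within the scatter) (an expected step). For compound 3 the estimated clearance is 1.6 mL/min/kg (expected range 0.9 mL/min/kg to 3 mL/min/kg).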

Compound 3, clearance: 1.48 mL/min/kg
Compound 3: the middle estimate sits 1.1-fold (0.03 log units) above what was measured, and the stated range covers the measured number.
By their numbers in this assay, from the lowest: compounds 3, 2 and 1 (each within the scatter of the next).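

In this assay, inverting this one saturated ring carbon gives a 1.0-fold lower number from compound 1 to compound 3 (0.02 log units; within the scatter), so the configuration drawn at this position leaves the clearance level within the scatter. For the compounds shown here, the earlier step spoke only to the chain on the oxygen, whereas this pair is the first to put a ring stereocentre to the test. The comparison isolates that single feature, with nothing else in the structures to confound it: the fact that compounds 1 and 3 differ only in the configuration as drawn

The compounds shown leave open whether the other stereocentres of the shared core are equally silent in this measurement, and whether this inversion would stay as silent in compound 2, which carries the longer chain. They also leave open what clearance would follow if an amine replaced the hydroxyl on this carbon, or a carboxylic acid replaced the sulfonamide.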